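The source may hold more compounds than are shown below. What is called first, only, known or untested is meant among the compounds shown, and "the series" means these compounds.

Compound 3 `C[C@@H](O)[C@H]1C(=O)N2C(C(=O)OCOC(=O)OC(C)(C)C)=C(S[C@@H]3CN[C@H](C(=O)Nc4cccc(C(=O)O)c4)C3)[C@H](C)[C@H]12` is read in a physicochemical assay for metabolic stability, read by LC-MS, in phosphate buffer, with a stated time of 3 h, at pH 7.4, tested at 50 uM (a higher number here means that more of the compound is left, a lower number that less of the compound is left), only as a limit, > 95%. Compound 1 `C[C@@H](O)[C@H]1C(=O)N2C(C(=O)OCOC(=O)C(C)(C)C)=C(S[C@@H]3CN[C@H](C(=O)Nc4cccc(C(=O)O)c4)C3)[C@H](C)[C@H]12` likewise sits at a limit in this assay, > 95%. Compound 2 `CC(C)OC(=O)OCOC(=O)C1=C(S[C@@H]2CN[C@H](C(=O)Nc3cccc(C(=O)O)c3)C2)[C@H](C)[C@@H]2[C@@H]([C@@H](C)O)C(=O)N12` also reaches a limit there, > 95%. All three values rest at the limit of > 95% in this assay, at which 3 of the 3 values shown sit, so the steps a step that the two limits leave unreadable from compound 1 to compound 2, a step that the two limits leave unreadable from compound 1 to compound 3 and a step that the two limits leave unreadable from compound 2 to compound 3 cannot be sized. Compound 4 `CC(C)C(=O)OCOC(=O)C1=C(S[C@@H]2CN[C@H](C(=O)Nc3cccc(C(=O)O)c3)C2)[C@H](C)[C@@H]2[C@@H]([C@@H](C)O)C(=O)N12` is not yet measured. It differs from compound 3 by isopropyl in place of tert-butoxy on a carbonyl carbon. Among the compounds with values here, no measured step reads a size, so no step beyond the scatter is expected in this assay. Compound 4 is expected to remain at the same limit, an estimated step that the limit leaves unreadable from compound 3 to compound 4. For compound 4 the estimate is 97%, within 90% to 100%.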

Compound 4, percent of the compound remaining: > 95%
Compound 4: no number, only a limit (the forecaster's own chance of this, stated with the estimate: 90%); the middle value lies beyond the limit too.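

In this assay, the steps from compound 1, compound 2 and compound 3 to compound 4 cannot be read, as all four compounds sit at a limit: the limit of > 95% in this assay, at which 4 of the 4 values shown sit.

The compounds shown leave open how far these four differ in stability.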